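The source may report more compounds than this note shows. Statements on the series, on what has been measured and on what is new or still open speak of the compounds shown alone.

Of the compounds shown here, two have been tested so far in a functional assay on HL-60 cells (Homo sapiens) for cytotoxicity, read by MTT assay, with a stated time of 72 h (a lower number here means a stronger inhibitor, a higher number a weaker inhibitor), and neither returns a true number. Compound 1 (`C=C1CC[C@]23C(C(=O)OC)=CCC[C@H]2[C@]12C[C@H](c1ccoc1)O[C@H]2O[C@@H]3O`) reads >= 10000 nM in this assay, which is a limit of the assay and not a number. Compound 2 (`COC(=O)C1=CCC[C@@H]2[C@]13CC[C@H](C)[C@@]21C[C@H](c2ccoc2)O[C@H]1O[C@@H]3O`) reads >= 10000 nM in this assay, which is also a limit. Compound 2 therefore stands at the limit of >= 10000 nM in this assay, at which 2 of the 2 values shown sit, and no exact potency is known for it. The next compound, compound 3 (`COC(=O)C1=CCC[C@@H]2[C@]13CC[C@H](C)[C@@]21C[C@H](c2ccoc2)O[C@H]1O[C@H]3O`), is related to compound 2 by one small change: the two compounds have the same atoms and bonds and differ only in configuration as drawn: 1 of 7 stereo elements differ; a stereocentre at a saturated ring carbon is drawn S in compound 2 and R in compound 3. Within the data shown here, no measured pair in this set shows what such a change in configuration does, so the data give no size or direction for it. The expected a number no higher from compound 2 to compound 3 (the limit leaves the size open) is none beyond the usual scatter of this assay, and another reading at the limit is the most likely outcome. Compound 3 is estimated at 10000 nM in this assay, with an expected range from 4000 nM to 20000 nM if a number is reported at all.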

Compound 3, half-maximal inhibitory concentration: >= 10000 nM
Compound 3 gave a limit, no number; the forecaster's own chance of this, stated with the estimate: 85%; the middle value sits exactly at the limit.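

No step can be read from compound 2 to compound 3 in this assay, since each gives only a limit and not a number: the limit of >= 10000 nM in this assay, at which 3 of the 3 values shown sit. The compounds shown leave open whether the change in configuration at the saturated ring carbon alters potency at all, and in which direction it would do so.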